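Hemolysis notes on the series, compound 2 to compound 3

This account rests on a few compounds, and the source may have more. Where it says the series, first, only, none or still open, it means among the compounds named here.

In an ADME assay on cells (Erythrocyte, Homo sapiens) for activation, read by hemolysis, with a stated time of 30 min, tested at 2.5 mM (on this read-out lower numbers stand for a weaker effect and higher numbers for a stronger effect at the one concentration tested), compound 1 `N=C(N)c1ccc(-c2ccc(-c3cc(Cl)cc(Cl)c3)s2)s1` is recorded only as "non-toxic" (no number reported), with no number behind it. For the measured compounds named here, compound 2 `COc1ccc(-c2ccc(-c3ccc(C(=N)N)o3)o2)cc1` gives 8.1% and thus holds the only numerical entry in this assay; no step between measured compounds can be drawn from it. Compound 3 `N=C(N)c1ccc(-c2ccc(-c3ccc(Cl)cc3)o2)o1` has not been measured. It differs from compound 2 by chloro in place of methoxy on an aromatic carbon. Going by the values given here, with no measured step to lean on, the step from compound 2 to compound 3 is estimated at a number 0.9 percentage points higher from compound 2 to compound 3 (within the scatter), which is none beyond the usual scatter. Compound 3 is therefore expected to give 9% in this assay, within a range of 0% to 22%.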

Compound 3, a percentage reported as activity, at one concentration (the size of the read-out at that concentration, not a potency): 41.3%
Compound 3: the middle estimate sits 32.3 percentage points below what was measured, outside the stated range (above it).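

Para to a large group, this position is not silent in this assay: chloro in place of methoxy gives a clear change (a number 33.2 percentage points higher from compound 2 to compound 3 (beyond the scatter)). For the compounds shown here, this is the first measured step, and it shows that a swap of one small group at this aromatic carbon can move hemolysis beyond the scatter. Nothing measured here accounts for the size of this step.

On these data alone, it remains open whether the step reflects the arrival of chloro or the departure of methoxy. Also open, as far as these compounds go, is how an amine, a carboxylic acid or a longer chain at this place would read in this assay on the same core.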